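A few compounds are considered here, and "the series" means these few. Any claim that something is new, unique, unknown or untested is made for them only; others in the source may bear on it.

Working notes on the series. Two compounds have numbers in an ADME assay on J774 cells (Mus musculus) for cytotoxicity, read by MTT assay, with a stated time of 48 h, tested at 150 ug/mL (on this read-out higher numbers stand for a weaker effect at the one concentration tested and lower numbers for a stronger effect), so far. Compound 1, `O=C(N/N=C/c1ccc(Cl)cc1)c1cnccn1`, is the lower of the two: in this assay compound 1 gives 56%. For the measured compounds named here, compound 2, `O=C(N/N=C/c1cccc(Br)c1)c1cnccn1`, gives 93% in this assay, a number that stands well above that of compound 1, beyond the usual scatter; the two differ in more than one place, so their pair shows only these two values and no single step.

The next compound, compound 3, `O=C(N/N=C/c1ccc(Br)cc1)c1cnccn1`, differs from compound 1 in one place: bromo in place of chloro on an aromatic carbon. Going by the values given here, the only other halogen-bearing compound, compound 2, sits at the weaker end of the read-out, but it is not a one-place neighbour of compound 1, so the size of this step has no measured counterpart.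

The expectation for compound 3 is a modest step upward in this assay, of about a number 10 percentage points higher from compound 1 to compound 3 (within the scatter), on the edge of the scatter. On that basis compound 3 is estimated at 66% in this assay, with a range from 45% to 90%.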

Compound 3, a percentage reported as activity, at one concentration (the size of the read-out at that concentration, not a potency): 94%
The estimate for compound 3 lay 28 percentage points below the measured number; the whole stated range lies below it.
By their numbers in this assay, from the lowest: compound 1; then compounds 2 and 3 (each within the scatter of the next).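

In this assay, bromo in place of chloro on an aromatic carbon, para to a large group, gives a number 38 percentage points higher from compound 1 to compound 3 (beyond the scatter) and so gives the series its first one-place step. This position therefore responds strongly to the identity of the halogen, even though the change exchanges one heavy atom for another and leaves the counts of rings, hydrogen-bond donors and hydrogen-bond acceptors and the net charge as they were. Nothing measured on these compounds accounts for the size of this step.

What the compounds shown leave open is how the read-out behaves with a group other than a halogen at this position, such as an amine, a methoxy group or a nitrile, which would show whether the number for compound 1 or the number for compound 3 is the more typical one for this place. Also open, on these data alone, is whether chloro in place of bromo on the aromatic carbon that carries bromo in compound 2 would produce a step of similar size, or whether this sensitivity belongs to the position of compound 1 and compound 3 alone.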